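Working notes: one untested change in a small paw-edema series

This account rests on a few compounds, and the source may have more. Where it says the series, first, only, none or still open, it means among the compounds named here.

Measured compounds
compound 1 `CCC(=O)N1N=C(c2ccc(C)cc2)CC1c1cn(-c2ccccc2)nc1-c1ccc(Cl)c(Cl)c1`: 70.3%
compound 2 `CCC(=O)N1N=C(c2ccc(Cl)cc2)CC1c1cn(-c2ccccc2)nc1-c1ccc(Cl)c(Cl)c1`: 68.8%

Both numbers come from a functional assay on the whole organism (strain Wistar) for inhibition, with Rattus norvegicus as the target, read by paw edema, with stated times of 30 min and 120 min, at a dose of 50 mg/kg by the oral route; a higher number here means more inhibition at the dose given (going by the name of the read-out), a lower number less inhibition. Compound 1 holds the higher of the two, but the step of a number 1.5 percentage points lower from compound 1 to compound 2 (within the scatter) lies within the scatter, so the two compounds cannot be ordered on these data.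

Compound 3 `Cc1ccc(C2=NN(c3ccccc3)C(c3cn(-c4ccccc4)nc3-c3ccc(Cl)c(Cl)c3)C2)cc1` has not been measured in this assay. It differs from compound 1 at the ring nitrogen of the shared core: phenyl in place of propanoyl on an amine nitrogen in a ring

Among the measured compounds shown here, the only measured step, a number 1.5 percentage points lower from compound 1 to compound 2 (within the scatter), concerns a chloro in place of methyl on an aromatic carbon, a different place, and is itself within the scatter. For the measured compounds named here, no measured step bears on the exchange of propanoyl for phenyl on the ring nitrogen, so nothing here supports a step in either direction. The working expectation is therefore a step of about a number 5.3 percentage points lower from compound 1 to compound 3 (within the scatter), with wide uncertainty. Compound 3 is estimated at 65%, within a range of 48% to 78%.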

Compound 3, a percentage reported as inhibition, in the whole organism at one dose (the size of the read-out at that dose, not a potency): 62.5%
Estimate against measurement, compound 3: 2.5 percentage points above; measured number inside the range.
By their numbers in this assay, from the lowest: compounds 3, 2 and 1 (each within the scatter of the next).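

In this assay, the ring nitrogen of the shared core now has a measured change: phenyl in place of propanoyl gives a number 7.8 percentage points lower from compound 1 to compound 3 (within the scatter). Among the compounds shown here, this step is the first at this position and, with the larger aromatic group replacing the acyl chain, the data show no separable difference in inhibition at this single oral dose, so the propanoyl carbonyl is not needed for a read-out of this size in this pair. No measurement at hand explains the result.

Going by these compounds, the series shows only these two groups on this nitrogen, so a benzyl group, a longer acyl chain or a carboxylic acid remains open. Also open, on these data alone, is whether the same exchange would read alike with chloro in place of methyl on the 4-methylphenyl group.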